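Shortening the nitrooxy chain from compound 3 to compound 4

This account rests on a few compounds, and the source may have more. Where it says the series, first, only, none or still open, it means among the compounds named here.

In a functional assay on Calu-1 cells (Homo sapiens) for cytotoxicity, read by resazurin assay, with a stated time of 72 h (on this read-out lower numbers stand for stronger inhibition and higher numbers for weaker inhibition), compound 1 `COc1cc(/C=C/C(=O)OCCCCCCO[N+](=O)[O-])ccc1O` gives > 50000 nM, which is a limit of the assay and not a number. Among the compounds with values here, compound 3 `COc1cc(/C=C/C(=O)OCCCCCO[N+](=O)[O-])ccc1O` gives 26300 nM, the higher of the two actual numbers so far, while compound 2 `COc1cc(/C=C/C(=O)OCCCO[N+](=O)[O-])ccc1OCCCO[N+](=O)[O-]` gives 1420 nM, lower by a gap beyond the scatter.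

Compound 4 `COc1cc(/C=C/C(=O)OCCCO[N+](=O)[O-])ccc1O` has yet to be measured. It differs from compound 3 by nitrooxy in place of 2-(nitrooxy)ethyl on a saturated chain carbon, three bonds along the chain from an oxygen next to a carbonyl group.

Within the data shown here, one measured step bears on this change: an at least 1.9-fold lower number from compound 1 to compound 3 (0.27 log units; that floor lies within the scatter). There, nitrooxy takes the place of (nitrooxy)methyl on a saturated chain carbon, five bonds along the chain from an oxygen next to a carbonyl group. That step starts from a limit, so only its floor is known, and that floor lies within the scatter. Among the measured compounds shown here, no measured step joins compound 2 to compound 3 or compound 4.

A somewhat lower number is therefore expected in this assay, probably not beyond the scatter. The expected step is a 1.6-fold lower number from compound 3 to compound 4 (0.22 log units; within the scatter). For compound 4 the estimated value is 16000 nM, with an expected range from 6000 nM to 45000 nM.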

Compound 4, half-maximal inhibitory concentration: > 50000 nM
Compound 4 ended at the assay's limit; the forecaster's own chance of this, stated with the estimate: 15%; middle value at least 3.1-fold (0.49 log units) away from the limit.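

Shortening the chain at this position gives an at least 1.9-fold higher number from compound 3 to compound 4 (0.27 log units; that floor lies within the scatter) in this assay, so the direction of this floor is opposite to that of the earlier step, an at least 1.9-fold lower number from compound 1 to compound 3 (0.27 log units; that floor lies within the scatter), although neither floor clears the scatter. Among compound 1, compound 3 and compound 4, only the compound with the middle chain length gives an actual number, so the three show no steady trend with chain length. The result also isolates the oxygen on the aromatic ring, where hydrogen in place of 3-(nitrooxy)propyl gives an at least 35-fold higher number from compound 2 to compound 4 (1.54 log units; beyond the scatter), which ties the low number of compound 2 to that group, since the chain on the ester is the same in both compounds.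

Compound 1 and compound 4 both stand at a limit, so the steps between them cannot be read: the limit of > 50000 nM in this assay, at which 2 of the 4 values shown sit.

Going by these compounds, it remains open how far compound 1 and compound 4 lie past that limit, and whether the nitrooxy group on the aromatic oxygen matters or a plain propyl chain there would serve as well. Equally open, on these data alone, is what a longer chain or a carboxylic acid at that oxygen would give.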